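This account rests on a few compounds, and the source may have more. Where it says the series, first, only, none or still open, it means among the compounds named here.

Compound 2 `COc1cc(-c2nnc(SCc3ccccc3)n2N2C(=O)c3ccccc3C2=O)cc(OC)c1OC` stands at the edge of what a functional assay on MKN-45 cells (Homo sapiens) for cytotoxicity, read by MTT assay, with a stated time of 48 h (on this read-out higher numbers stand for weaker inhibition and lower numbers for stronger inhibition), can resolve: in this assay compound 2 gives > 200000 nM, which is a limit rather than a number. Compound 1 `C=CCSc1nnc(-c2cc(OC)c(OC)c(OC)c2)n1N1C(=O)c2ccccc2C1=O` gives > 200000 nM in this assay, likewise a limit. The step that the two limits leave unreadable from compound 1 to compound 2 therefore has no readable size. Compound 3 `COc1ccc(C(=O)CSc2nnc(-c3cc(OC)c(OC)c(OC)c3)n2N2C(=O)c3ccccc3C2=O)cc1` differs from compound 2 by (4-methoxyphenyl)carbonyl in place of phenyl on a saturated chain carbon bound to a sulfur. Among the measured compounds shown here, no measured step bears readably on this change; both values shown sit at the limit of > 200000 nM in this assay, at which 2 of the 2 values shown sit. Compound 3 is therefore expected to give 200000 nM in this assay, within 50000 nM to 400000 nM, most probably again as a limit. The estimated step of a number no higher from compound 2 to compound 3 (the limit leaves the size open) is expected not to exceed the scatter.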

Compound 3, half-maximal inhibitory concentration: 37200 nM
The estimate for compound 3 lay 5.4-fold (0.73 log units) above the measured number; measured number outside the range, below it.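

In this assay, this position proves able to move the read-out: (4-methoxyphenyl)carbonyl in place of phenyl gives an at least 5.3-fold lower number from compound 2 to compound 3 (0.73 log units; beyond the scatter), and in place of vinyl it gives an at least 5.3-fold lower number from compound 1 to compound 3 (0.73 log units; beyond the scatter). Going by these compounds, both steps are lower bounds, so their full size remains unknown. Compound 3 is the only compound shown with a readable number, the other two remaining at a limit: the limit of > 200000 nM in this assay, at which 2 of the 3 values shown sit.

The compounds shown do not separate the contribution of the carbonyl from that of the methoxy group. They also leave open what an amine or a carboxylic acid would give on this saturated chain carbon.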